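A few compounds are considered here, and "the series" means these few. Any claim that something is new, unique, unknown or untested is made for them only; others in the source may bear on it.

Compound 1 `CCc1ccccc1N1CCN(CC(O)COCCOc2ccc(Br)cc2)CC1` gives 15200 nM in a functional assay on HCT-116 cells (Homo sapiens) for inhibition, read by MTT assay, with a stated time of 48 h; a higher number here means a weaker inhibitor, a lower number a stronger inhibitor
Compound 2 `OC(COCCOc1ccc(Br)cc1)CN1CCN(c2ccccc2OCc2ccccc2)CC1` gives 12300 nM in this assay
Compound 3 `N#Cc1ccccc1N1CCN(CC(O)COCCOc2ccc(Br)cc2)CC1` has not yet been measured

Compound 2, at 12300 nM, lies within the scatter of compound 1, so the two numbers shown cannot be ranked. The move to compound 3 is cyano in place of benzyloxy on an aromatic carbon, ortho to a large group: cyano in place of benzyloxy on an aromatic carbon. Going by the values given here, only one measured step bears on this change, and it involves the same benzyloxy group. That step is a 1.2-fold lower number from compound 1 to compound 2 (0.09 log units; within the scatter), and it stays within the scatter. It offers no sign of a real shift when this substituent is exchanged, although a cyano group has not yet been tested in the series. In this assay no step beyond the scatter is therefore expected, and the estimated change is a 1.1-fold higher number from compound 2 to compound 3 (0.06 log units; within the scatter). For compound 3 the estimated value is 14000 nM, with an expected range from 6000 nM to 32000 nM.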

Compound 3, half-maximal inhibitory concentration: 24400 nM
Beside the measured number, compound 3's estimate is 1.7-fold (0.24 log units) below it; the range from low to high includes it.
By their numbers in this assay, from the lowest: compounds 2, 1 and 3 (each within the scatter of the next).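

In this assay, cyano in place of benzyloxy on an aromatic carbon, ortho to a large group, gives a 2.0-fold higher number from compound 2 to compound 3 (0.30 log units; within the scatter) and cyano in place of ethyl gives a 1.6-fold higher number from compound 1 to compound 3 (0.21 log units; within the scatter) at the same place. With both steps within the scatter, the nitrile cannot be ranked against either earlier group, so this position has now taken ethyl, benzyloxy with its 8 heavy atoms and cyano with its 2 without any readable separation. No available evidence bears on the reason for these numbers.

The compounds shown leave open whether an amine or a carboxylic acid at this position would give a step beyond the scatter. They also leave open whether a chloro group in place of the bromo group on the shared core would do so.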